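Working notes: amide substituent change from compound 3

This account rests on a few compounds, and the source may have more. Where it says the series, first, only, none or still open, it means among the compounds named here.

In an ADME assay on microsomes from liver (Mus musculus, strain CD-1) for metabolic stability, read by LC-MS, tested at 2 uM (a lower number here means that the compound disappears faster, a higher number that the compound lasts longer), compound 1 (`Cn1ccc2ccc(-c3cc(Nc4ccccc4S(N)(=O)=O)cc4nccnc34)cc21`) gives 0.5 h and compound 2 (`Cn1ccc2ccc(-c3cc(Nc4ccccc4S(=O)(=O)N4CCOCC4)cc4nccnc34)cc21`) gives 0.367 h as half-life. Compound 3 (`Cn1cc(CNC(=O)c2ccncc2Nc2cc(-c3ccc4ccn(C)c4c3)c3nccnc3c2)cn1`) gives 0.267 h and stands within the scatter of both. Compound 4 (`CC(=O)N1CCCC(NC(=O)c2ccncc2Nc2cc(-c3ccc4ccn(C)c4c3)c3nccnc3c2)C1`) has 1-acetylpiperidin-3-yl in place of (1-methyl-1H-pyrazol-4-yl)methyl on an amide-type nitrogen. Going by the values given here, the only measured step is a 1.4-fold lower number from compound 1 to compound 2 (0.13 log units; within the scatter) at a sulfonyl sulfur, a different place, and it stays within the scatter. Among the compounds with values here, no measured step covers the amide-type nitrogen, so no step beyond the scatter is expected in this assay here. The estimated step is a 1.1-fold higher number from compound 3 to compound 4 (0.05 log units; within the scatter) and lies within the scatter. Compound 4 is expected at 0.3 h with an estimated range of 0.15 h to 0.6 h as half-life.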

Compound 4, half-life: 0.4 h
Compound 4: middle estimate off by 1.3-fold (0.12 log units), on the low side, within the range that was stated.
By their numbers in this assay, from the lowest: compounds 3, 2, 4 and 1 (each within the scatter of the next).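

Going by these compounds alone, at the amide-type nitrogen, the change to 1-acetylpiperidin-3-yl from (1-methyl-1H-pyrazol-4-yl)methyl gives in this assay a 1.5-fold higher number from compound 3 to compound 4 (0.18 log units; within the scatter), the first reading at this position. Replacing the five-membered aromatic ring with a six-membered non-aromatic ring, with a larger group overall, therefore leaves the half-life within the scatter. Nothing available gives a reason for this result.

As far as these compounds go, whether a plain methyl, a longer alkyl chain or a chain ending in a carboxylic acid on this nitrogen would give a step beyond the scatter remains open.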